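Bromine on the Shared Indole Unit and HCT-15 Cytotoxicity

The source may report more compounds than this note shows. Statements on the series, on what has been measured and on what is new or still open speak of the compounds shown alone.

Compound 1, `O=C1NC[C@@H](c2c[nH]c3ccccc23)N[C@H]1c1c[nH]c2ccccc12`: in an ADME assay on HCT-15 cells (Homo sapiens) for cytotoxicity (on this read-out lower numbers stand for an effect already at smaller amounts and higher numbers for an effect only at larger amounts of compound), compound 1 gives > 10 ug/mL, which is a limit of the assay and not a number.
Compound 2, `O=C(C1=NC(c2c[nH]c3ccccc23)CN1)c1c[nH]c2cc(Br)ccc12`: in this assay compound 2 gives > 30 ug/mL, again a limit rather than a number.
Compound 3, `O=C(C1=NC(c2c[nH]c3cc(Br)ccc23)CN1)c1c[nH]c2cc(Br)ccc12`: in this assay compound 3 gives 4.88 ug/mL.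

Compound 1 and compound 2 have different cores; the difference between the two cores is not broken down here. Compound 2 and compound 3 differ by one change, (bromo in place of hydrogen on an aromatic carbon), and this change produced an at least 6.1-fold lower number from compound 2 to compound 3 (0.78 log units; beyond the scatter). Compound 4, `O=C1NC[C@@H](c2c[nH]c3cc(Br)ccc23)N[C@H]1c1c[nH]c2ccccc12`, is not yet measured; it differs from compound 1 by bromo in place of hydrogen on an aromatic carbon, the same change on a matching place.

Since compound 1 sits at a limit, only a lower bound of its starting point is known. The step from compound 1 to compound 4 is expected to be an at least 2.0-fold lower number from compound 1 to compound 4 (0.30 log units; that floor lies within the scatter), because the same change gave an at least 6.1-fold lower number from compound 2 to compound 3 (0.78 log units; beyond the scatter). On that basis compound 4 is estimated at 5 ug/mL, plausibly between 1.5 ug/mL and 15 ug/mL.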

Compound 4, concentration for half-maximal effect: 6.3 ug/mL
Beside the measured number, compound 4's estimate is 1.3-fold (0.10 log units) below it, within the range that was stated.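

Carried onto the core of compound 1, bromo in place of hydrogen on an aromatic carbon again goes with a lower number in this assay, with an at least 1.5-fold lower number from compound 1 to compound 4 (0.20 log units; that floor lies within the scatter). The direction seen on the other core therefore recurs, although the smallest size this step could have does not clear the usual scatter. Both steps start from a limit, so they give only minimum sizes and cannot show whether the change does the same amount on each core: the same change on two cores in this assay, an at least 6.1-fold lower number (0.78 log units; beyond the scatter) from compound 2 to compound 3 and an at least 1.5-fold lower number (0.20 log units; that floor lies within the scatter) from compound 1 to compound 4; the limit leaves it open whether they differ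

The compounds shown leave open what the true numbers behind the limits of compound 1 and compound 2 are, and whether the change would hold on a third core, since two cores make a repeat and not a rule for the series. They also leave open whether a different group at the same place, such as chloro, a methoxy group or an amine, would go the same way as bromo.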